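A few compounds are considered here, and "the series" means these few. Any claim that something is new, unique, unknown or untested is made for them only; others in the source may bear on it.

Compound 1, `COc1cc(C(=O)c2cn(-c3cccc(C)c3)cc2-c2ccccc2[N+](=O)[O-])cc(OC)c1OC`, gives 220 nM in a functional assay on MCF7 cells (Homo sapiens) for cytotoxicity, read by MTT assay, with a stated time of 96 h; a higher number here means a weaker inhibitor, a lower number a stronger inhibitor.
Compound 2, `COc1cc(C(=O)c2cn(-c3cccc(F)c3)cc2-c2ccccc2[N+](=O)[O-])cc(OC)c1OC`, gives 190 nM in this assay.
Compound 3, `COc1cc(C(=O)c2cn(-c3ccc(C)cc3)cc2-c2ccccc2F)cc(OC)c1OC`, gives 44 nM in this assay.

Compound 1 and compound 2 share one core and differ in a single place: fluoro in place of methyl on an aromatic carbon. That change gave a 1.2-fold lower number from compound 1 to compound 2 (0.06 log units; within the scatter), so the two numbers tell the same story and neither compound can be called the stronger of the pair. Compound 3 stands on a different core from compound 1, and the difference between the two cores is not broken down here; what can be said is that compound 3 gives the lowest of the three numbers in this assay, with both other compounds beyond the scatter above it.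

Compound 4, `COc1cc(C(=O)c2cn(-c3ccc(F)cc3)cc2-c2ccccc2F)cc(OC)c1OC`, is not yet measured. It differs from compound 3 by fluoro in place of methyl on an aromatic carbon. Among the compounds with values here, this is the same kind of change as the one from compound 1 to compound 2, not the very same one: there the fluoro sat meta to a large group, here it sits para to a large group, and the core is another.

Within the data shown here, the expectation for compound 4 rests on the one measured instance of this kind of change, which gave a 1.2-fold lower number from compound 1 to compound 2 (0.06 log units; within the scatter). On that basis the step is expected to be small, a 1.1-fold lower number from compound 3 to compound 4 (0.04 log units; within the scatter). Among the measured compounds shown here, compound 4 is therefore estimated to give 40 nM in this assay, most likely between 18 nM and 90 nM, with the width of that range reflecting that the step is known from only one other pair on a different core.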

Compound 4, half-maximal inhibitory concentration: 39 nM
The estimate for compound 4 lay 1.0-fold (0.01 log units) above the measured number; measured number inside the range.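

In this assay, putting fluoro in place of methyl on the aromatic carbon para to a large group gave a 1.1-fold lower number from compound 3 to compound 4 (0.05 log units; within the scatter), so the numbers of this pair cannot be told apart. Set beside the earlier pair, the change behaves alike on the two cores: the same change on two cores in this assay, a 1.2-fold lower number (0.06 log units; within the scatter) from compound 1 to compound 2 and a 1.1-fold lower number (0.05 log units; within the scatter) from compound 3 to compound 4, 1.0-fold (0.01 log units) apart, within the scatter of two such steps. This shows that, in both pairs available, swapping methyl for fluoro left the number where it was whichever core carried it, which makes the earlier pair a fair guide to the later one; it does not show that the swap would be just as quiet on every core in the series or at every position on the ring, and two pairs are too few to support a general rule.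

The pairs shown exchange only methyl and fluoro, so it stays open whether an amine, a carboxylic acid or a longer chain at the same place would also leave the number unmoved. From the compounds shown here alone, it is also open whether the quiet result for methyl and fluoro would carry over to any read-out other than this assay.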